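Replacing a Difluorophenyl Ring with a Hydroxyphenyl Ring

A few compounds are considered here, and "the series" means these few. Any claim that something is new, unique, unknown or untested is made for them only; others in the source may bear on it.

Compound 1 `COc1cc(/C=C2\CCC/C(=C\c3ccc(F)c(F)c3)C2=O)cc(OC)c1OC` and compound 2 `COc1cc(/C=C2\CCC/C(=C\c3ccccc3F)C2=O)cc(OC)c1OC` share one core and differ only in the aromatic ring hanging from it. In a functional assay on HT-29 cells (Homo sapiens) for antiproliferative activity, read by MTT assay, with a stated time of 72 h (on this read-out lower numbers stand for stronger inhibition and higher numbers for weaker inhibition), compound 1 gives 1700 nM, and compound 2 gives 1600 nM. Compound 1 thus carries the higher of the two numbers, but the step of a 1.1-fold lower number from compound 1 to compound 2 (0.03 log units; within the scatter) lies within the scatter, so the two compounds cannot be told apart on this evidence. Compound 3 `COc1cc(/C=C2\CCC/C(=C\c3cccc(O)c3)C2=O)cc(OC)c1OC` has not yet been measured; it differs from compound 1 by 3-hydroxyphenyl in place of 3,4-difluorophenyl on a double-bonded chain carbon bound to a double-bonded ring carbon. Within the data shown here, the only measured step that bears on this change is the one from compound 1 to compound 2, which exchanged one fluorinated ring for another without any shift beyond the scatter, and a 3-hydroxyphenyl ring has no measured precedent here. Compound 3 is therefore expected to land near compound 1, with the step of a 1.1-fold lower number from compound 1 to compound 3 (0.05 log units; within the scatter) estimated at no more than the scatter. The estimate for compound 3 in this assay is 1500 nM, with a range from 500 nM to 4500 nM.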

Compound 3, half-maximal inhibitory concentration: 7600 nM
Compound 3: the middle estimate sits 5.1-fold (0.70 log units) below what was measured, and the stated range ends below it.
By their numbers in this assay, from the lowest: compounds 2 and 1 (each within the scatter of the next); then compound 3.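

This position is not indifferent to the ring it carries. In this assay the two fluorinated rings gave numbers within the scatter of each other, but the hydroxylated ring gives a 4.5-fold higher number from compound 1 to compound 3 (0.65 log units; beyond the scatter) and a 4.8-fold higher number from compound 2 to compound 3 (0.68 log units; beyond the scatter) and both steps point towards weaker inhibition. Compared with 3,4-difluorophenyl, the 3-hydroxyphenyl ring has 1 hydrogen-bond donor and 1 hydrogen-bond acceptor and no fluorine, yet nothing available explains why this change weakens the result.

The compounds shown leave open whether the added hydroxyl or the lost fluorine matters more, and whether moving the hydroxyl elsewhere on the ring would change the outcome. A 3-methoxyphenyl ring, which caps the oxygen with a methyl group, or a 3-aminophenyl ring would help separate these possibilities.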